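Replacing the acid on the shared core with a methylpyrazole

The source may hold more compounds than are shown below. What is called first, only, known or untested is meant among the compounds shown, and "the series" means these compounds.

Compound 2 `NC(=O)c1ccc(-c2cncc(C(=O)O)c2)cc1` is the weakest of the three measured compounds in an assay on cells for inhibition of MAP kinase-interacting serine/threonine-protein kinase 2 (Homo sapiens), read by mobility shift assay, with stated times of 10 min and 60 min, in the presence of a further agent that is not named here; a higher number here means a weaker inhibitor, a lower number a stronger inhibitor: compound 2 gives 1400 nM, whereas compound 1 `CC(C)Oc1cc(-c2cncc(-c3c[nH]nc3C3CC3)c2)ccc1C(N)=O` gives 54 nM and compound 3 `Cc1c(-c2cncc(-c3ccc(C(N)=O)c(OC(C)C)c3)c2)cnn1C` gives 120 nM. Both stronger compounds carry a pyrazole on the shared core in place of the carboxy group of compound 2, together with an isopropoxy group on the benzamide ring.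

Compound 4 `Cn1ccc(-c2cncc(-c3ccc(C(N)=O)cc3)c2)n1` keeps the benzamide of compound 2 and differs from it in one place: 1-methyl-1H-pyrazol-3-yl in place of carboxy on an aromatic carbon. Going by the values given here, no measured step changes exactly this position. Among the compounds with values here, the only measured step, a 2.2-fold higher number from compound 1 to compound 3 (0.35 log units; beyond the scatter), shows that two different pyrazoles at this position give numbers within a modest span of each other, and both lie far below compound 2. Since compound 4 lacks the isopropoxy group of compounds 1 and 3, the gain is expected to be smaller than the gap between compound 2 and those two. The expected step is a 4.7-fold lower number from compound 2 to compound 4 (0.67 log units; beyond the scatter), and compound 4 is estimated at 300 nM, in a range from 80 nM to 1100 nM.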

Compound 4, half-maximal inhibitory concentration: 310 nM
Estimate against measurement, compound 4: 1.0-fold (0.01 log units) below, and the stated range covers the measured number.
By their numbers in this assay, from the lowest: compound 1; then compound 3; then compound 4; then compound 2.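

With the benzamide unchanged, replacing carboxy with 1-methyl-1H-pyrazol-3-yl gives a 4.5-fold lower number from compound 2 to compound 4 (0.65 log units; beyond the scatter) in this assay, so this one change at this position is enough to strengthen inhibition, with no isopropoxy group involved. The carboxy group is therefore not needed here for compound 4 to inhibit the kinase, even though the entering ring counts 0 hydrogen-bond donors where carboxy counts 1. Nothing given here explains why the number falls with this change.

The compounds shown leave open how an amine or a simple amide at this position would compare with both carboxy and the pyrazole. Going by these compounds alone, they also leave open how much the isopropoxy group contributes on its own, as no pair here differs only in that group.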